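Changing the ring on the amine nitrogen: compound 4

A few compounds are considered here, and "the series" means these few. Any claim that something is new, unique, unknown or untested is made for them only; others in the source may bear on it.

In a functional assay on CHO cells with adenosine receptor A1 (Homo sapiens) as the target, read by cAMP accumulation and immunoassay, with a stated time of 6 min, tested at 0.01 uM (a lower number here means a stronger effect, a higher number a weaker effect of the compound at the concentration tested), compound 3 `Nc1scc(CN2CCN(c3ccccc3F)CC2)c1C(=O)c1ccc(Cl)cc1` gives 2.1%, the highest of the three numbers shown, though compound 2 `Nc1scc(CN2CCN(c3ccc(OC(F)(F)F)cc3)CC2)c1C(=O)c1ccc(Cl)cc1` with 0% lies within the scatter of it; only compound 1 `Nc1scc(CN2CCN(c3ccc(Cl)cc3F)CC2)c1C(=O)c1ccc(Cl)cc1` with -9.2% sits beyond it, as a number 11.3 percentage points higher from compound 1 to compound 3 (beyond the scatter) shows. Compound 4 `Nc1scc(CN2CCN(c3ccc(F)c(Cl)c3)CC2)c1C(=O)c1ccc(Cl)cc1` differs from compound 3 in one place: 3-chloro-4-fluorophenyl in place of 2-fluorophenyl on an amine nitrogen in a ring. The measured swaps of the ring on the amine nitrogen are a number 9.2 percentage points higher from compound 1 to compound 2 (within the scatter) and a number 2.1 percentage points higher from compound 2 to compound 3 (within the scatter), both within the scatter, while a number 11.3 percentage points higher from compound 1 to compound 3 (beyond the scatter) is modest. All three measured numbers stay near zero. For compound 4 the expected step is therefore a number 2.1 percentage points lower from compound 3 to compound 4 (within the scatter), none beyond the scatter. Compound 4 is estimated at 0%, with a range from -12% to 12%.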

Compound 4, a percentage reported as activity, at one concentration (the size of the read-out at that concentration, not a potency): 4.2%
The estimate for compound 4 lay 4.2 percentage points below the measured number, and the stated range covers the measured number.
By their numbers in this assay, from the lowest: compounds 1, 2, 3 and 4 (each within the scatter of the next, the first and the last beyond it).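

In this assay a chlorine and a fluorine placed as in 3-chloro-4-fluorophenyl leave the number in place, with a number 2.1 percentage points higher from compound 3 to compound 4 (within the scatter) and a number 4.2 percentage points higher from compound 2 to compound 4 (within the scatter) as the steps. Among the compounds shown here, the only step beyond the scatter is a number 13.4 percentage points higher from compound 1 to compound 4 (beyond the scatter) and it is modest, so among the four aryl groups on this amine nitrogen, compound 1 differs only from compound 3 and compound 4. Nothing available explains these steps. As far as these compounds go, whether a pyridine ring, or a phenyl ring bearing a carboxylic acid or an amine, would carry the number clearly away from zero remains open.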